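Butylsulfanyl for Cyclopropylamino on a Shared Purine-Like Core

A few compounds are considered here, and "the series" means these few. Any claim that something is new, unique, unknown or untested is made for them only; others in the source may bear on it.

Compound 2 `Nc1nc(NC2CC2)c2ncn(/C=C3/CC3(CO)CO)c2n1` was tested in an ADME assay on Akata cells (Homo sapiens) for cytotoxicity, with a stated time of 7 days; a higher number here means that more compound is tolerated, a lower number that less compound is tolerated. In this assay compound 2 gives > 20000 nM, which is a limit of the assay and not a number. The two companions measured alongside it stand in the same place. Compound 1 `C=CCOc1nc(N)nc2c1ncn2/C=C1/CC1(CO)CO` gives > 20000 nM, again a limit of the assay. Compound 3 `Nc1nc2c(ncn2/C=C2/CC2(CO)CO)c(=O)[nH]1` gives > 20000 nM, likewise a limit. The only step that joins two of these compounds in one place, a step that the two limits leave unreadable from compound 1 to compound 2, cannot be sized, because the limit of > 20000 nM in this assay, at which 3 of the 3 values shown sit, covers both of its ends.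

Compound 4 `CCCCSc1nc(N)nc2c1ncn2/C=C1/CC1(CO)CO` differs from compound 2 by butylsulfanyl in place of cyclopropylamino on an aromatic carbon. Within the data shown here, no measured step offers a readable size for this kind of change, so the expectation rests on where the three measured compounds sit. Since every value shown is a limit, compound 4 is expected to show no step beyond the scatter, a number no higher from compound 2 to compound 4 (the limit leaves the size open). Compound 4 is therefore estimated at 20000 nM, between 8000 nM and 40000 nM, with the most likely outcome once more a limit rather than a number.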

Compound 4, half-maximal cytotoxic concentration: > 20000 nM
Compound 4: no number, only a limit; the forecaster's own chance of this, stated with the estimate: 75%; the middle value sits exactly at the limit.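

The steps joining compound 4 to compound 1 and to compound 2 cannot be read, because their ends lie at one limit: the limit of > 20000 nM in this assay, at which 4 of the 4 values shown sit.

The compounds shown leave open whether the groups exchanged on the shared core differ at all in this assay.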